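Trifluoromethyl moved on the shared core: compound 4

A few compounds are considered here, and "the series" means these few. Any claim that something is new, unique, unknown or untested is made for them only; others in the source may bear on it.

compound 1 `Nc1nc2ccccn2c1-c1ccc(O)cc1`: > 100000 nM
compound 2 `CN(C)c1nc2ccccn2c1-c1ccc(O)cc1`: > 100000 nM
compound 3 `Nc1nc2cc(C(F)(F)F)ccn2c1-c1ccc(O)cc1`: > 100000 nM

In an assay on isolated protein for inhibition of ubiquitin carboxyl-terminal hydrolase 14 (Homo sapiens) (on this read-out higher numbers stand for weaker inhibition and lower numbers for stronger inhibition), compound 1 gives only a limit of the assay, not a number. Compound 2 likewise gives only a limit. Compound 3 likewise gives only a limit. Compound 4 `Nc1nc2c(C(F)(F)F)cccn2c1-c1ccc(O)cc1` differs from compound 1 by trifluoromethyl in place of hydrogen on an aromatic carbon. The two steps already measured from compound 1 are a step that the two limits leave unreadable from compound 1 to compound 2 and a step that the two limits leave unreadable from compound 1 to compound 3; neither has a readable size, since (the limit of > 100000 nM in this assay, at which 3 of the 3 values shown sit). The change to compound 4 carries the same trifluoromethyl onto the same ring at another aromatic carbon as in compound 3, which itself sits at the limit. No readable step is therefore available, and no step beyond the scatter is expected from compound 1 to compound 4 in this assay, estimated as a step that the limit leaves unreadable from compound 1 to compound 4. Compound 4 is expected to give 150000 nM in this assay, with a range from 40000 nM to 600000 nM, and most probably to be reported only as a limit again.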

Compound 4, half-maximal inhibitory concentration: > 100000 nM
Compound 4: a limit, no number (the forecaster's own chance of this, stated with the estimate: 85%); the middle value does not contradict the limit.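

In this assay compound 4 gives > 100000 nM, a limit and not a number, so no step from compound 1 to compound 4 can be read: the limit of > 100000 nM in this assay, at which 4 of the 4 values shown sit.

The compounds shown leave open whether any change on the shared core gives a readable value.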